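A few compounds are considered here, and "the series" means these few. Any claim that something is new, unique, unknown or untested is made for them only; others in the source may bear on it.

Compounds sharing one core have been run in a functional assay on MDA-MB-231 cells (Homo sapiens) for inhibition, read by MTT assay, with a stated time of 72 h; on this read-out higher numbers stand for weaker inhibition and lower numbers for stronger inhibition: compound 1 `CC(C)[C@H](NC(=O)c1cc(Cl)ccc1OCCNC(=O)O)C(=O)Nc1ccc([N+](=O)[O-])cc1Cl`, compound 2 `CC(C)COC(=O)NCCOc1ccc(Cl)cc1C(=O)N[C@H](C(=O)Nc1ccc([N+](=O)[O-])cc1Cl)C(C)C` and compound 3 `CC(C)[C@H](NC(=O)c1cc(Cl)ccc1OCCCNC(=O)OC(C)(C)C)C(=O)Nc1ccc([N+](=O)[O-])cc1Cl`. In this assay compound 1 gives only a limit, > 10000 nM. Compound 2 gives a number in this assay, 4900 nM. Compound 3 in this assay also returns only a limit, > 10000 nM, so it stands at the weak edge of the series with no number to read. Two of the three values thus sit at the limit of > 10000 nM in this assay, at which 2 of the 3 values shown sit.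

Compound 4 `CC(C)[C@H](NC(=O)c1cc(Cl)ccc1OC1CCNCC1)C(=O)Nc1ccc([N+](=O)[O-])cc1Cl` differs from compound 3 by piperidin-4-yl in place of 3-((tert-butoxycarbonyl)amino)propyl on an oxygen on an aromatic ring. The measured steps that touch compound 3 are of little help: the step that the two limits leave unreadable from compound 1 to compound 3 is unreadable, and the step of an at least 2.0-fold higher number from compound 2 to compound 3 (0.30 log units; that floor lies within the scatter) reaches only the floor of the scatter. The step of an at least 2.0-fold lower number from compound 1 to compound 2 (0.30 log units; that floor lies within the scatter) likewise lies at the floor. Going by the values given here, no measured step concerns a ring amine on the aromatic oxygen, so nothing fixes the direction of the new step, and a change beyond the scatter in either direction cannot be ruled out. Because compound 3 stands at > 10000 nM, a limit, the expected step of an at least 1.4-fold lower number from compound 3 to compound 4 (0.15 log units; that floor lies within the scatter) is estimated from the limit downward. Compound 4 is expected to give about 7000 nM, in the range 1500 nM to 30000 nM.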

Compound 4, half-maximal inhibitory concentration: 5230 nM
For compound 4 the middle estimate is 1.3-fold (0.13 log units) above the measured one; measured number inside the range.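

In this assay, the place on an oxygen on an aromatic ring accepts a six-membered non-aromatic ring as well as an open chain: a 1.1-fold higher number from compound 2 to compound 4 (0.03 log units; within the scatter), so piperidin-4-yl and 2-((isobutoxycarbonyl)amino)ethyl cannot be told apart on this read-out. Against the other two chains, the printed steps reach only floors: an at least 1.9-fold lower number from compound 3 to compound 4 (0.28 log units; that floor lies within the scatter) and an at least 1.9-fold lower number from compound 1 to compound 4 (0.28 log units; that floor lies within the scatter), so neither establishes a gain beyond the scatter from this change. The true size of both steps stays unknown, as compound 1 and compound 3 are held at a limit and not at a number: the limit of > 10000 nM in this assay, at which 2 of the 4 values shown sit.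

The compounds shown do not separate the contribution of the ring from that of its nitrogen, which a cyclohexyl group in place of piperidin-4-yl would address, nor do they show what a methyl on the ring nitrogen would do. Also open, from the compounds shown here alone, is whether a free primary amine on a propyl chain at the same oxygen would match compound 4 or give a step beyond the scatter.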